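The compounds below may be only part of what the source reports. "The series", "measured", "known", "first", "only" and "open" are said of these compounds alone.

Of the compounds shown here, three that share one core have been tested in a functional assay on UACC-257 cells (Homo sapiens) for inhibition, read by sulforhodamine B assay, with a stated time of 48 h; on this read-out lower numbers stand for stronger inhibition of growth and higher numbers for weaker inhibition of growth. Compound 1 `N#C/C(=C\c1c(-c2ccccc2)[nH]c2ccccc12)C(=O)c1ccccc1` gives 10900 nM in this assay. Compound 2 `CCOC(=O)C(=Cc1c(-c2ccccc2)[nH]c2ccccc12)C(=O)OCC` gives 7500 nM, and compound 3 `COc1ccc(-c2[nH]c3ccccc3c2/C=C(\C#N)S(=O)(=O)c2ccccc2)cc1` gives 10700 nM. Compound 1 carries the highest of the three numbers, but every gap between them lies within the usual scatter, so no order can be read from them.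

The next compound, compound 4 `N#C/C(=C\c1c(-c2ccccc2)[nH]c2ccccc12)S(=O)(=O)c1ccccc1`, differs from compound 1 in a single group: phenylsulfonyl in place of benzoyl on a double-bonded chain carbon bound to a double-bonded chain carbon and a triple-bonded carbon. For the measured compounds named here, no two measured compounds differ in just one place, so no measured step shows directly what this exchange does. Compound 3 carries the same phenylsulfonyl group beside its nitrile and gives 10700 nM, a number that sits close to compound 1, which suggests the exchange leaves the growth inhibition roughly where it is.

The step from compound 1 to compound 4 is therefore expected to be a 1.1-fold lower number from compound 1 to compound 4 (0.04 log units; within the scatter), nothing beyond the scatter. Compound 4 is estimated at 10000 nM, within a range from 4000 nM to 25000 nM.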

Compound 4, concentration for 50% growth inhibition: 18200 nM
Compound 4: the middle estimate sits 1.8-fold (0.26 log units) below what was measured; measured number inside the range.
By their numbers in this assay, from the lowest: compounds 2, 3, 1 and 4 (each within the scatter of the next, the first and the last beyond it).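

In this assay, phenylsulfonyl in place of benzoyl on a double-bonded chain carbon gives a 1.7-fold higher number from compound 1 to compound 4 (0.22 log units; within the scatter), so this direct comparison shows no difference between the two groups that can be separated from the scatter. Hydrogen in place of methoxy on an aromatic carbon gives a 1.7-fold higher number from compound 3 to compound 4 (0.23 log units; within the scatter), so the methoxy group also has no effect that can be told apart from the scatter. No measurement at hand accounts for either step.

Going by these compounds, whether a different kind of group on that chain carbon, such as a carboxylic acid or an amine, would move the number beyond the scatter remains open. The same question stands for the aromatic carbon, where a fluorine atom or a longer chain such as butoxy could be compared with hydrogen and methoxy.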